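From Ethyl to Fluoro on an Aromatic Ring

The source may hold more compounds than are shown below. What is called first, only, known or untested is meant among the compounds shown, and "the series" means these compounds.

Compound 1 `CCc1ccc(SCc2ccc(C(=O)Nc3ccccc3N)cc2)cc1` gives 1740 nM
Compound 2 `Nc1ccccc1NC(=O)/C=C/c1ccc(CSc2cccc3ccccc23)cc1` gives "not determined" (no result reported)

Going by the values given here, in a functional assay on HCT-116 cells (Homo sapiens) for antiproliferative activity, read by CCK-8 assay, with a stated time of 72 h (on this read-out higher numbers stand for weaker inhibition and lower numbers for stronger inhibition), compound 1 gives 1740 nM and is the only compound with a number so far. Compound 2 has no result, so there is nothing to rank compound 1 against, and it cannot yet be called strong or weak within this small set.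

The next compound, compound 3 `Nc1ccccc1NC(=O)c1ccc(CSc2ccc(F)cc2)cc1`, keeps the core of compound 1 and alters one place (fluoro in place of ethyl on an aromatic carbon). This is fluoro in place of ethyl on an aromatic carbon, so 4-ethylphenyl becomes 4-fluorophenyl.

Among the compounds with values here, no pair of measured compounds shows what a single change does in this assay, so the data give no guide to size or direction. With no evidence favouring either direction, no shift beyond the usual scatter of repeated measurements is expected. The estimated change is small (a 1.2-fold lower number from compound 1 to compound 3 (0.06 log units; within the scatter)). This expectation rests on compound 1 alone (1740 nM), so the range is kept wide. For compound 3 the expected value is 1500 nM (estimated range 500 nM to 4500 nM).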

Compound 3, half-maximal inhibitory concentration: 4010 nM
Estimate against measurement, compound 3: 2.7-fold (0.43 log units) below; measured number inside the range.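

In this assay, replacing 4-ethylphenyl with 4-fluorophenyl on the shared core gives a 2.3-fold higher number from compound 1 to compound 3 (0.36 log units; beyond the scatter) and provides the first measured sign that this position on the aromatic ring can affect the result. Because a higher number means weaker inhibition, this single change goes in the unfavourable direction, and the shift is larger than repeat measurements alone would usually produce, although it remains modest. This is still one step between one pair of compounds, so it sets no general rule for the position, and no measurement available here bears on what causes the shift.

The step also leaves open whether the loss follows from removing the ethyl group or from introducing fluoro, since both happen in the same change and neither is tested separately. Other groups on the same aromatic carbon, such as a bare hydrogen, methyl, a longer propyl chain, chloro or an amine, would help to separate these two readings and show whether anything at this position can improve on the ethyl group.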